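The source may report more compounds than this note shows. Statements on the series, on what has been measured and on what is new or still open speak of the compounds shown alone.

Going by the values given here, compound 1 `COC(=O)Nc1cc(-c2cc(Cl)c(OC[C@@](C)(N)CC(C)C)cn2)ccn1` was tested in an assay on brain (strain C57BL6) for displacement of a labelled ligand from AP2-associated protein kinase 1 (Mus musculus), read by scintillation counting, with a stated time of 1 h (a higher number here means a weaker inhibitor, a lower number a stronger inhibitor), where compound 1 gives 0.11 nM, the lowest of the two numbers measured so far. Its nearest neighbour, compound 2 `COC(=O)Nc1cc(-c2cc(C)c(OC[C@@](C)(N)CC(C)C)cn2)ccn1`, gives 1.4 nM in this assay, and the single-place step a 13-fold higher number from compound 1 to compound 2 (1.10 log units; beyond the scatter) counts as large. Among the compounds with values here, compound 3 `Cc1cc(-c2cc(Cl)c(OC[C@@](C)(N)CC(C)C)cn2)ccn1` differs from compound 1 by methyl in place of (methoxycarbonyl)amino on an aromatic carbon, a change at a different position from the one in that measured step, so no measured step bears directly on it. The expected step of a 45-fold higher number from compound 1 to compound 3 (1.66 log units; beyond the scatter) is toward a weaker inhibitor. The estimate for compound 3 is 5 nM, within a range from 0.5 nM to 100 nM.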

Compound 3, inhibition constant: 0.7 nM
Beside the measured number, compound 3's estimate is 7.1-fold (0.85 log units) above it; low and high end bracket the measured number.
By their numbers in this assay, from the lowest: compound 1; then compounds 3 and 2 (each within the scatter of the next).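

Compound 1's earlier partner changed only the chloro group, whereas this change, on an aromatic carbon next to the ring nitrogen, shows that the (methoxycarbonyl)amino group also matters, with a 6.4-fold higher number from compound 1 to compound 3 (0.80 log units; beyond the scatter). Even so, the much smaller methyl leaves a strong inhibitor, so the full group is not required for tight binding in this assay. Nothing available explains the size of this step.

Going by these compounds, an amine or a longer chain such as ethyl at this position remains open. Also open, on these data alone, is whether this step would keep its size with the methyl of compound 2 in place of chloro.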